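The source may hold more compounds than are shown below. What is called first, only, known or untested is meant among the compounds shown, and "the series" means these compounds.

Compounds measured in an assay on HEK293 cells for binding affinity to Urotensin-2 receptor (Homo sapiens), read by radioligand binding; on this read-out lower numbers stand for stronger inhibition and higher numbers for weaker inhibition:
compound 1 `Cc1cc(C(=O)N[C@H]2CCN(Cc3ccc(OCCCN(C)C)cc3)C2)ccc1Cl` gives 631 nM.
compound 3 `Cc1cc(C(=O)N[C@H]2CCN(Cc3ccc(OCCCN(C)C)cc3)C2)ccc1Br` gives 631 nM.
compound 2 `Cc1ccc(C(=O)N[C@H]2CCN(Cc3ccc(OCCCN(C)C)cc3)C2)cc1C` gives < 10000 nM, which is a limit of the assay and not a number.

Compound 1 stands level with compound 3 at the digits shown; the step of no change at the digits printed from compound 1 to compound 3 (within the scatter) lies within the scatter. Compound 2 sits at a limit (the limit of < 10000 nM in this assay, at which 1 of the 3 values shown sits). Hence the step that the limit leaves unreadable from compound 1 to compound 2 is unreadable, as is a step that the limit leaves unreadable from compound 2 to compound 3.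

Compound 4 `CN(C)CCCOc1ccc(CN2CC[C@H](NC(=O)c3ccc(C#N)cc3)C2)cc1` is yet to be measured in this assay. It differs from compound 1 by 4-cyanophenyl in place of 4-chloro-3-methylphenyl on a carbonyl carbon. Within the data shown here, no measured step covers this change directly: the halogen swap from compound 1 to compound 3 left the value unchanged, while the step to the methyl analogue cannot be sized. The cyano group replaces both the chloro and the methyl at once, so the expectation rests on little. Compound 4 is expected to bind somewhat more weakly than compound 1, the step of a 3.2-fold higher number from compound 1 to compound 4 (0.50 log units; beyond the scatter) being an estimate that may exceed the scatter but is uncertain. The estimate for compound 4 is 2000 nM, with a range from 500 nM to 10000 nM, and a fair chance that only a limit is reported.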

Compound 4, inhibition constant: < 10000 nM
Compound 4 ended at the assay's limit; the forecaster's own chance of this, stated with the estimate: 30%; the middle value does not contradict the limit.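

No step from compound 4 to compound 1, compound 2 or compound 3 can be read, because compound 4 stands at a limit and not at a number: the limit of < 10000 nM in this assay, at which 2 of the 4 values shown sit.

The compounds shown leave open the size of the change from 4-chloro-3-methylphenyl to 4-cyanophenyl, and whether compound 2 and compound 4 differ at all.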